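Methyl for fluoro on the secondary amine analogue

This account rests on a few compounds, and the source may have more. Where it says the series, first, only, none or still open, it means among the compounds named here.

Measured compounds:
compound 1 `CN1[C@H](COc2cccnc2F)C[C@H]2C[C@H]21` gives 31.9 nM
compound 2 `Cc1ncccc1OC[C@@H]1C[C@H]2C[C@H]2N1C` gives 231 nM
compound 3 `Fc1ncccc1OC[C@@H]1C[C@H]2C[C@H]2N1` gives 17.4 nM

In an assay on CHO-K1 cells for displacement of a labelled ligand from Neuronal acetylcholine receptor; alpha4/beta2 (Homo sapiens), read by scintillation counting (on this read-out lower numbers stand for stronger inhibition and higher numbers for weaker inhibition), compound 3 holds the lowest of the three numbers; the step of a 1.8-fold lower number from compound 1 to compound 3 (0.26 log units; within the scatter) is within the scatter, while compound 2 lies clearly higher, beyond the scatter. Compound 4 `Cc1ncccc1OC[C@@H]1C[C@H]2C[C@H]2N1` differs from compound 3 by methyl in place of fluoro on an aromatic carbon. Among the measured compounds shown here, the one measured step of this kind is a 7.2-fold higher number from compound 1 to compound 2 (0.86 log units; beyond the scatter), modest but beyond the scatter. The same change on compound 3 is therefore expected to give a step of similar size, a higher number, a 7.2-fold higher number from compound 3 to compound 4 (0.86 log units; beyond the scatter). Compound 4 is estimated at 125 nM, with a range from 55 nM to 280 nM.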

Compound 4, inhibition constant: > 10000 nM
Compound 4 ended at the assay's limit (the forecaster's own chance of this, stated with the estimate: 2%); at least 80-fold (1.90 log units) between middle value and limit.
By their numbers in this assay, from the lowest: compounds 3 and 1 (each within the scatter of the next); then compound 2. At a limit, above all of these: compound 4.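

Methyl in place of fluoro next to the ring nitrogen has no fixed size of effect; it depends on what the amine nitrogen carries, with the step on the secondary amine being an at least 570-fold higher number from compound 3 to compound 4 (2.75 log units; beyond the scatter): the same change on two cores in this assay, a 7.2-fold higher number (0.86 log units; beyond the scatter) from compound 1 to compound 2 and an at least 570-fold higher number (2.75 log units; beyond the scatter) from compound 3 to compound 4, at least 79-fold (1.89 log units) apart, beyond the scatter of two such steps.
Hydrogen in place of methyl on the amine nitrogen stays within the scatter with fluoro present, yet with methyl on the aromatic carbon it gives an at least 43-fold higher number from compound 2 to compound 4 (1.63 log units; beyond the scatter): the same change on two cores in this assay, a 1.8-fold lower number (0.26 log units; within the scatter) from compound 1 to compound 3 and an at least 43-fold higher number (1.63 log units; beyond the scatter) from compound 2 to compound 4, at least 79-fold (1.89 log units) apart, beyond the scatter of two such steps.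
Compound 4 stands at a limit of the assay, not at a number: the limit of > 10000 nM in this assay, at which 1 of the 4 values shown sits.

Going by these compounds, whether chloro or methoxy at this aromatic carbon behaves like fluoro or like methyl stays open. So does the effect of an ethyl group on the amine nitrogen.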